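Taking the Methyl Group off Compound 1

The compounds below may be only part of what the source reports. "The series", "measured", "known", "first", "only" and "open" are said of these compounds alone.

In a functional assay on LNCaP cells (Homo sapiens) for cytotoxicity, read by MTT assay, with a stated time of 5 days (a higher number here means a weaker inhibitor of growth, a lower number a stronger inhibitor of growth), compound 1 (`Cc1ccc(NS(=O)(=O)c2ccccc2)c([N+](=O)[O-])c1`) gives 2.95 nM and compound 2 (`Cc1ccc(NS(=O)(=O)c2ccc(F)cc2)c([N+](=O)[O-])c1`) gives 2.34 nM as its result. Within the data shown here, these two numbers lie within the usual scatter of each other, so compound 1 stands level with the only other compound measured so far.

Compound 3 (`O=[N+]([O-])c1ccccc1NS(=O)(=O)c1ccccc1`) differs from compound 1 in one place (hydrogen in place of methyl on an aromatic carbon) with hydrogen in place of methyl on an aromatic carbon. Among the measured compounds shown here, no measured step removes or adds a methyl group, so the evidence is thin. For the measured compounds named here, the one measured step is a 1.3-fold lower number from compound 1 to compound 2 (0.10 log units; within the scatter) for fluoro in place of hydrogen on an aromatic carbon. It is a different change, and it bears only loosely, but it shows one small swap that stays within the scatter.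

On that basis, no step beyond the scatter is expected in either direction in this assay and the estimated step is a 1.2-fold higher number from compound 1 to compound 3 (0.07 log units; within the scatter) with wide uncertainty. For compound 3 the expected value is 3.5 nM with an estimated range from 1.2 nM to 10 nM for repeated measurements.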

Compound 3, concentration for 50% growth inhibition: 14.8 nM
Beside the measured number, compound 3's estimate is 4.2-fold (0.63 log units) below it; measured number outside the range, above it.
By their numbers in this assay, from the lowest: compounds 2 and 1 (each within the scatter of the next); then compound 3.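

Among these compounds, this position, an aromatic carbon meta to a nitro group and para to a large group, gives the first single change that moves the number beyond the scatter in this assay (a 5.0-fold higher number from compound 1 to compound 3 (0.70 log units; beyond the scatter)). Among the compounds shown here, a higher number here means a weaker inhibitor of growth, so removing one methyl group, only a single carbon with no ring and no net charge, leaves compound 3 measurably weaker than compound 1, whereas the earlier fluoro swap stayed within the scatter (a 1.3-fold lower number from compound 1 to compound 2 (0.10 log units; within the scatter)). Nothing available here explains what the methyl group contributes at this position.

From the compounds shown here alone, it remains open whether this carbon favours methyl in particular or would accept other groups, such as an ethyl group, a chlorine atom or a methoxy group, which could show how much the size and kind of group matter. Going by these compounds, it also remains open how an amine or a carboxylic acid would fare at the same place, and whether the drop seen on removing methyl would recur in the fluoro-bearing compound 2.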